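The compounds below may be only part of what the source reports. "The series", "measured", "known", "first", "only" and "open" are said of these compounds alone.

Compound 1, `O=C(/C=C/c1ccc(OCc2cn(Cc3ccccc3)nn2)cc1)c1ccc(Br)cc1`, is the starting point of this small set. In a functional assay on HepG2 cells (Homo sapiens) for inhibition, read by MTT assay, with a stated time of 48 h, tested at 10 uM (a higher number here means more inhibition of growth at the concentration tested, a lower number less inhibition of growth), compound 1 gives 22%. Compound 2, `O=C(/C=C/c1ccc(OCc2cn(Cc3ccc(Br)cc3)nn2)cc1)c1ccc(Br)cc1`, carries the change (bromo in place of hydrogen on an aromatic carbon), and in this assay compound 2 gives 22%. The step of no change at the digits printed from compound 1 to compound 2 (within the scatter) therefore lies within the scatter of the measurement; on this pair the added bromine left the reading where it was.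

Compound 3, `O=C(/C=C/c1ccc(OCc2cn(Cc3ccccc3)nn2)cc1)c1ccc([N+](=O)[O-])cc1`, has a different core: the difference between the two cores is nitro in place of bromo on an aromatic carbon. Compound 3 is reported in this assay as "not active" (no number reported), so no single number stands for it, only the statement that it showed no activity at the concentration tested.

Compound 4, `O=C(/C=C/c1ccc(OCc2cn(Cc3ccccc3Br)nn2)cc1)c1ccc([N+](=O)[O-])cc1`, has not yet been measured. It differs from compound 3 by bromo in place of hydrogen on an aromatic carbon. Within the data shown here, this is the same kind of change as the one from compound 1 to compound 2, but not the same: in the measured pair the bromine sits para to a large group, whereas in compound 4 it sits ortho to a large group.

Among the measured compounds shown here, the only guidance for compound 4 is the pair of compounds 1 and 2, where no change at the digits printed from compound 1 to compound 2 (within the scatter) was without visible effect, and compound 3, which has no number at all. Compound 4 is therefore expected to stay close to compound 3, with an estimated reading of 10% in this assay, between 0% and 25%, and with a real chance that again only the absence of activity is reported.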

Compound 4, percent growth inhibition at one concentration: 32%
Estimate against measurement, compound 4: 22 percentage points below; measured number above the stated range.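

In this assay, among these compounds, compound 3 is recorded as "not active" (no number reported) and compound 4 gives 32% so no step from compound 3 to compound 4 can be read, as compound 3 has no number. The compounds shown leave open how a bromo group ortho to a large group compares with one elsewhere on the same core. Nothing shown here offers an explanation for the reading of compound 4.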